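Fluoro in place of chloro: expectation for compound 3

The compounds below may be only part of what the source reports. "The series", "measured", "known", "first", "only" and "open" are said of these compounds alone.

In an ADME assay on THP-1 cells (Homo sapiens) for cytotoxicity, read by MTT assay, with a stated time of 24 h (on this read-out higher numbers stand for weaker inhibition and lower numbers for stronger inhibition), compound 1 `O=C(OCc1cn(-c2ccccc2)nn1)[C@@H]1CCCN1` gives 780000 nM and compound 2 `O=C(OCc1cn(-c2ccc(Cl)cc2)nn1)[C@@H]1CCCN1` gives 346000 nM, the lower of the two numbers. Compound 3 `O=C(OCc1cn(-c2ccc(F)cc2)nn1)[C@@H]1CCCN1` carries fluoro in place of chloro on an aromatic carbon, para to a large group: fluoro in place of chloro on an aromatic carbon. Going by the values given here, only one measured step bears on this change: a 2.3-fold lower number from compound 1 to compound 2 (0.35 log units; beyond the scatter), a modest one, with chloro in place of hydrogen. Among the compounds with values here, no measured step involves fluoro. A small move to a higher number in this assay is expected, possibly no larger than the scatter. The expected step is a 1.4-fold higher number from compound 2 to compound 3 (0.14 log units; within the scatter). For compound 3 the estimated value is 480000 nM, with an expected range of 260000 nM to 850000 nM.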

Compound 3, half-maximal inhibitory concentration: 309000 nM
The estimate for compound 3 lay 1.6-fold (0.19 log units) above the measured number; the measured number falls inside the stated range.
By their numbers in this assay, from the lowest: compounds 3 and 2 (each within the scatter of the next); then compound 1.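

Para to a large group on the aromatic ring, in this assay, fluoro in place of chloro gives a 1.1-fold lower number from compound 2 to compound 3 (0.05 log units; within the scatter), so this change does not separate the two halogens. Fluoro in place of hydrogen gives a 2.5-fold lower number from compound 1 to compound 3 (0.40 log units; beyond the scatter), a step beyond the scatter, so the shift first seen with chloro also appears with a second halogen. No measurement at hand accounts for either step. Still open, from the compounds shown here alone, is whether a non-halogen group at this position, such as an amine, methoxy or a carboxylic acid, moves the number in the same direction. Also open, going by these compounds, is whether any change on this ring reaches beyond a modest step.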